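The source may report more compounds than this note shows. Statements on the series, on what has been measured and on what is new or still open speak of the compounds shown alone.

Compound 1 `O=C(Nc1ccc(Oc2ccnc3[nH]ccc23)cc1)c1cn(-c2ccc(Br)cc2)c2ccccc2c1=O` — in a functional assay on MCF7 cells (Homo sapiens) for inhibition, read by MTT assay, with a stated time of 72 h (a lower number here means a stronger inhibitor, a higher number a weaker inhibitor), compound 1 gives 610 nM.
Compound 2 `COc1ccc(-n2cc(C(=O)Nc3ccc(Oc4ccnc5[nH]ccc45)cc3)c(=O)c3ccccc32)cc1` — in this assay compound 2 gives 4650 nM.

Among the compounds with values here, compound 1 stands lowest of the two numbers; the only other measured compound lies above it by a 7.6-fold higher number from compound 1 to compound 2 (0.88 log units; beyond the scatter). Compound 3 `O=C(Nc1ccc(Oc2ccnc3[nH]ccc23)c(F)c1)c1cn(-c2ccc(Br)cc2)c2ccccc2c1=O` differs from compound 1 by fluoro in place of hydrogen on an aromatic carbon. Within the data shown here, the single measured step, a 7.6-fold higher number from compound 1 to compound 2 (0.88 log units; beyond the scatter), concerns a different site on the core and offers no direct guide to this change, so no step beyond the scatter is expected in this assay in either direction. Compound 3 is therefore estimated at 600 nM, with a range of 250 nM to 1500 nM, which amounts to an expected 1.0-fold lower number from compound 1 to compound 3 (0.01 log units; within the scatter).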

Compound 3, half-maximal inhibitory concentration: 650 nM
Compound 3: the middle estimate sits 1.1-fold (0.03 log units) below what was measured, within the range that was stated.
By their numbers in this assay, from the lowest: compounds 1 and 3 (each within the scatter of the next); then compound 2.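

In this assay, the step from hydrogen to fluoro, on an aromatic carbon ortho to a large group and meta to a large group, is a 1.1-fold higher number from compound 1 to compound 3 (0.03 log units; within the scatter), so the carbon carries this one added fluorine atom without a step beyond the scatter. Within the data shown here, this is the first reading at this position, since the earlier step concerned another site. No measured evidence bears on the result.

On these data alone, whether an amine or a carboxylic acid at this carbon would also stay within the scatter remains open. So does whether fluoro would give the same reading on compound 2, which carries methoxy in place of bromo.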